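The source may report more compounds than this note shows. Statements on the series, on what has been measured and on what is new or still open speak of the compounds shown alone.

Measured compounds:
compound 1 `CCN(CC)c1ccc2cc(C(=O)c3ccc(N4CCN(C(=O)CN5CCN(C(=O)CCl)CC5)CC4)cc3)oc2c1` with 1630 nM
compound 2 `CCN(CC)c1ccc2cc(C(=O)c3ccc(N4CCN(C(=O)CN5CCN(Cc6ccc(/C=C/C(=O)OC)cc6)CC5)CC4)cc3)oc2c1` with 740 nM

In a functional assay on SGC-7901 cells (Homo sapiens) for cytotoxicity, read by MTT assay, with a stated time of 48 h (on this read-out lower numbers stand for stronger inhibition and higher numbers for weaker inhibition), compound 1 gives the highest of the two numbers; compound 2 gives a lower one, beyond the scatter. Compound 3 `CCOC(=O)CN1CCN(CC(=O)N2CCN(c3ccc(C(=O)c4cc5ccc(N(CC)CC)cc5o4)cc3)CC2)CC1` is not yet measured. It differs from compound 1 by (ethoxycarbonyl)methyl in place of (chloromethyl)carbonyl on an amine nitrogen in a ring. Going by the values given here, no step between measured compounds shows what this change does, so the expected step from compound 1 to compound 3 in this assay is small, a 1.4-fold lower number from compound 1 to compound 3 (0.13 log units; within the scatter), and may well lie within the scatter. Compound 3 is therefore expected to give about 1200 nM, with a range from 400 nM to 3500 nM.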

Compound 3, half-maximal inhibitory concentration: > 40000 nM
Compound 3: no number, only a limit; the forecaster's own chance of this, stated with the estimate: 5%; middle value at least 33-fold (1.52 log units) from the limit.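

In this assay, (ethoxycarbonyl)methyl in place of (chloromethyl)carbonyl on this amine nitrogen in a ring gives an at least 24-fold higher number from compound 1 to compound 3 (1.38 log units; beyond the scatter), so the group at this position can decide whether the compound registers at all. Ethoxycarbonyl in place of 4-(2-(methoxycarbonyl)ethenyl)phenyl on the saturated chain carbon gives an at least 54-fold higher number from compound 2 to compound 3 (1.73 log units; beyond the scatter), so the two earlier groups both stand well apart from this one. For compound 3 this is a limit and not a number: the limit of > 40000 nM in this assay, at which 1 of the 3 values shown sits.

The compounds shown leave open whether a carboxylic acid in place of the ethyl ester would change this result. They also leave open what a simple acetyl or benzyl group on the same nitrogen would give.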